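Fluoro for methyl on the indazole of compound 2

The source may report more compounds than this note shows. Statements on the series, on what has been measured and on what is new or still open speak of the compounds shown alone.

Measured compounds:
Compound 1 `CC/C(=C(/c1ccc(/C=C/C(=O)O)cc1)c1cc2cn[nH]c2cc1C)c1ccccc1`, in a functional assay on MCF7 cells (Homo sapiens) for cytotoxicity, read by CellTiter-Glo, with a stated time of 5 days (a higher number here means a weaker inhibitor, a lower number a stronger inhibitor), compound 1 gives 468 nM.
Compound 2 `CC/C(=C(/c1ccc(/C=C/C(=O)O)cc1)c1cc(C)c2[nH]ncc2c1)c1ccccc1`, in this assay compound 2 gives 59 nM.

Going by the values given here, compound 2 stands at the lowest of the two numbers in this assay; the one measured step, a 7.9-fold lower number from compound 1 to compound 2 (0.90 log units; beyond the scatter), moved the methyl from one position of the indazole to another. Compound 3 `CC/C(=C(/c1ccc(/C=C/C(=O)O)cc1)c1cc(F)c2[nH]ncc2c1)c1ccccc1` keeps the core of compound 2 and differs in one place: fluoro in place of methyl on an aromatic carbon. Among the compounds with values here, no measured step exchanges a methyl for a fluoro, so the step from compound 1 to compound 2 bears on it only in showing that this part of the molecule can shift the number by a modest amount. A small step in this assay, towards a slightly higher number, is therefore expected: a 1.7-fold higher number from compound 2 to compound 3 (0.23 log units; within the scatter). Compound 3 is estimated at 100 nM, within 35 nM to 300 nM.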

Compound 3, half-maximal inhibitory concentration: 7.5 nM
Compound 3: middle estimate off by 13-fold (1.12 log units), on the high side; the whole stated range lies above it.
By their numbers in this assay, from the lowest: compound 3; then compound 2; then compound 1.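

In this assay, the exchange of methyl for fluoro on this aromatic carbon, ortho to a fused ring, gives a 7.9-fold lower number from compound 2 to compound 3 (0.90 log units; beyond the scatter). The earlier step showed only that moving the methyl matters; this one shows that the methyl is not needed for a low number here, and that swapping one heavy atom for another at the same place can shift the result beyond the scatter. The 7-fluoro-1H-indazol-5-yl group in place of 6-methyl-1H-indazol-5-yl gives a 62-fold lower number from compound 1 to compound 3 (1.80 log units; beyond the scatter), the largest step among these compounds, and no measurement at hand explains the gain from fluoro.

Going by these compounds, it remains open how chloro, methoxy, nitrile or plain hydrogen would read on this carbon. On these data alone, it is also open whether the gain from fluoro would hold with an amide in place of the carboxylic acid.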